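One Side Chain Swapped: Compound 3 Becomes Compound 4

A few compounds are considered here, and "the series" means these few. Any claim that something is new, unique, unknown or untested is made for them only; others in the source may bear on it.

Three compounds share one core and differ only in the group on a carbonyl carbon. In a functional assay on A549 cells (Homo sapiens) for cytotoxicity, read by MTT assay, with a stated time of 72 h (a higher number here means a weaker inhibitor, a lower number a stronger inhibitor), compound 1 `COc1ncc(-c2ccc3nc(NC(=O)N4CCCC4)nn3c2)cc1NS(=O)(=O)c1ccc(F)cc1` gives 3570 nM, compound 2 `COc1ncc(-c2ccc3nc(NC(=O)N(C)C)nn3c2)cc1NS(=O)(=O)c1ccc(F)cc1` gives 1190 nM and compound 3 `COc1ncc(-c2ccc3nc(NC(=O)NCC(=O)N4CCCC4)nn3c2)cc1NS(=O)(=O)c1ccc(F)cc1` gives 2190 nM. Compound 3 cannot be told apart from either of the other two on these numbers. The measured steps are a 1.6-fold lower number from compound 1 to compound 3 (0.21 log units; within the scatter) and a 1.8-fold higher number from compound 2 to compound 3 (0.26 log units; within the scatter).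

Compound 4 `COc1ncc(-c2ccc3nc(NC(=O)NCCN4CCN(C)CC4)nn3c2)cc1NS(=O)(=O)c1ccc(F)cc1` has not yet been measured. It carries (4-methylpiperazin-1-yl)methyl in place of (pyrrolidin-1-yl)carbonyl on a saturated chain carbon bound to an amide-type nitrogen. Within the data shown here, the side chain therefore ends as 2-(4-methylpiperazin-1-yl)ethyl, a group that none of the measured compounds contains, so the evidence is only indirect.

The largest change seen so far at this part of the molecule is a 3.0-fold lower number from compound 1 to compound 2 (0.48 log units; beyond the scatter), which is modest. On that basis, no step beyond the scatter is expected in this assay. The expected step is a 1.2-fold lower number from compound 3 to compound 4 (0.09 log units; within the scatter). On these data alone, for compound 4 the estimated value is 1800 nM, with an expected range from 650 nM to 5000 nM, kept wide because the new group is untested.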

Compound 4, half-maximal inhibitory concentration: 1050 nM
Compound 4: the middle estimate sits 1.7-fold (0.23 log units) above what was measured, and the stated range covers the measured number.
By their numbers in this assay, from the lowest: compounds 4, 2, 3 and 1 (each within the scatter of the next, the first and the last beyond it).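

In this assay, among these compounds, replacing (pyrrolidin-1-yl)carbonyl with (4-methylpiperazin-1-yl)methyl on a saturated chain carbon bound to an amide-type nitrogen gives a 2.1-fold lower number from compound 3 to compound 4 (0.32 log units; beyond the scatter), the only step involving compound 3 that lies beyond the scatter, so the end of this side chain can shift the number, if only modestly. The long (2-(4-methylpiperazin-1-yl)ethyl)amino group still cannot be told apart from the short dimethylamino group on the same carbonyl carbon, with a 1.1-fold lower number from compound 2 to compound 4 (0.05 log units; within the scatter), but it does stand clear of pyrrolidin-1-yl, with a 3.4-fold lower number from compound 1 to compound 4 (0.53 log units; beyond the scatter). Nothing shown here explains why the number moves with this change.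

Compound 4 differs from compound 3 in both its ring and the loss of the side-chain carbonyl, so a 2-(morpholin-4-yl)ethyl group, a 2-(dimethylamino)ethyl group or a longer chain ending in the same 4-methylpiperazin-1-yl ring would be needed to show which part matters. On these data alone, it also remains open how a 4-methylpiperazin-1-yl group placed directly on the carbonyl carbon would compare with dimethylamino and pyrrolidin-1-yl.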